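Urea series at the vanilloid channel: trifluoromethoxy for trifluoromethyl

The source may hold more compounds than are shown below. What is called first, only, known or untested is meant among the compounds shown, and "the series" means these compounds.

Compound 1 `Cc1ccc(N2CCN(C(=O)Nc3ccc(C(F)(F)F)cc3)CC2)nn1` gives > 10000 nM in an assay on HEK293 cells for inhibition of transient receptor potential cation channel subfamily V member 1 (Homo sapiens), read by FLIPR, at pH 5.5 (on this read-out higher numbers stand for weaker inhibition and lower numbers for stronger inhibition), which is a limit of the assay and not a number.
Compound 2 `Cc1ccc(N2CCN(C(=O)Nc3ccc(OC(F)(F)F)cc3)CC2)nn1` gives > 10000 nM in this assay, again a limit.
Compound 3 `O=C(Nc1ccc(C(F)(F)F)cc1)N1CCN(c2nncc3ccccc23)CC1` gives > 10000 nM in this assay, again a limit.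

For the measured compounds named here, all three measured values sit at the limit of > 10000 nM in this assay, at which 3 of the 3 values shown sit, so no step can be read. The change from compound 1 to compound 2 is trifluoromethoxy in place of trifluoromethyl on an aromatic carbon, and on the read-out it made a step that the two limits leave unreadable from compound 1 to compound 2. Compound 3 carries a different core from compound 1; the difference between the two cores is not broken down here.

Compound 4 `O=C(Nc1ccc(OC(F)(F)F)cc1)N1CCN(c2nncc3ccccc23)CC1` is not yet measured. It stands to compound 3 as compound 2 stands to compound 1: the change is trifluoromethoxy in place of trifluoromethyl on an aromatic carbon, the same change as before, at the same place. Going by the values given here, since the earlier occurrence of this change left both ends at the limit, there is no measured size to carry over; the only information is that neither the trifluoromethyl nor the trifluoromethoxy compound on the core of compound 1 reached a readable number, and that compound 3 on its own core also did not.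

The step from compound 3 to compound 4 in this assay is therefore expected to be a step that the limit leaves unreadable from compound 3 to compound 4, resting on compound 3 at > 10000 nM and on the unreadable step before it. Compound 4 is estimated at 20000 nM, most likely reported again only as a limit, with a range of 7000 nM to 60000 nM.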

Compound 4, half-maximal inhibitory concentration: > 10000 nM
Compound 4: no number, only a limit; the forecaster's own chance of this, stated with the estimate: 85%; the middle value is on the limit's open side.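

No step to compound 4 can be read from compound 3 or from compound 2, because each of these values is a limit and not a number: the limit of > 10000 nM in this assay, at which 4 of the 4 values shown sit.

The compounds shown leave open whether trifluoromethoxy in place of trifluoromethyl alters inhibition on either core, and whether the core of compound 1 and that of compound 3 differ in this assay.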